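A Methoxy for a Methyl on the Benzyl Arm

The source may report more compounds than this note shows. Statements on the series, on what has been measured and on what is new or still open speak of the compounds shown alone.

Two compounds share a core and differ in their side groups. Compound 1 `CNC(=O)c1cc(C(=O)NC2CC2)cn(Cc2ccc(C)cc2)c1=O` and compound 2 `CNC(=O)c1cc(C(=O)NCC(C)C)cn(Cc2ccccc2)c1=O` were both tested in a physicochemical assay for lipophilicity, at pH 7.4; a higher number here means a more lipophilic compound, a lower number a more polar compound. In this assay compound 1 gives 3.5, while compound 2 gives 4.3, a gap beyond the usual scatter, so compound 1 stands as the lower of the two numbers available. Among the measured compounds shown here, the two compounds differ in more than one place, so no single step between them can be traced.

Compound 3 `CNC(=O)c1cc(C(=O)NC2CC2)cn(Cc2cccc(OC)c2)c1=O` has not yet been measured. It differs from compound 1 in one place: 3-methoxyphenyl in place of 4-methylphenyl on a saturated chain carbon bound to an aromatic nitrogen. For the measured compounds named here, with no measured pair showing this exact change, the direction has to be judged from the change itself. For compound 3 a modest drop in this assay is expected, a step of a number 0.60 log units lower from compound 1 to compound 3 (beyond the scatter) from compound 1, with compound 3 estimated at 2.9, most likely between 2.4 and 3.4.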

Compound 3, distribution coefficient: 3
Beside the measured number, compound 3's estimate is 0.10 log units below it, within the range that was stated.
By their numbers in this assay, from the lowest: compound 3; then compound 1; then compound 2.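

In this assay, among the compounds shown here, 3-methoxyphenyl in place of 4-methylphenyl on a saturated chain carbon bound to an aromatic nitrogen gives a number 0.50 log units lower from compound 1 to compound 3 (beyond the scatter), the first step in this set that can be traced to one place. The earlier pair differed in more than one place, so it could not show that this position alone can move the number by more than the scatter. The data offer no measured reason for this step.

Still open, going by these compounds, is whether the step follows the added oxygen or the different place of the group on the ring, and a 3-methylphenyl group at the same position would help separate the two. On these data alone, how a carboxylic acid on that ring would read in this assay is also open.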